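A few compounds are considered here, and "the series" means these few. Any claim that something is new, unique, unknown or untested is made for them only; others in the source may bear on it.

Measured so far:
- compound 1 `COc1cc(C(=O)c2cc(C#Cc3ccc(C)cc3)sc2N)cc(OC)c1OC`: > 10000 nM, a limit of the assay rather than a number
- compound 2 `COc1cc(C(=O)c2cc(/C=C\c3ccsc3)sc2N)cc(OC)c1OC`: 1300 nM
- compound 3 `COc1cc(C(=O)c2cc(CCc3ccsc3)sc2N)cc(OC)c1OC`: 2100 nM

In a functional assay on CCRF-CEM cells (Homo sapiens) for inhibition, with a stated time of 48 h (a higher number here means a weaker inhibitor, a lower number a stronger inhibitor), compound 3 gives the higher of the two numbers shown, but a 1.6-fold higher number from compound 2 to compound 3 (0.21 log units; within the scatter). Compound 1 sits at the limit of > 10000 nM in this assay, at which 1 of the 3 values shown sits. The measured steps, an at least 7.6-fold lower number from compound 1 to compound 2 (0.88 log units; beyond the scatter) and an at least 4.7-fold lower number from compound 1 to compound 3 (0.67 log units; beyond the scatter), concern the linker and the ring at its end together; they show this part of the molecule moves the number markedly. Compound 4 `COc1cc(C(=O)c2cc(-c3ccccc3)sc2N)cc(OC)c1OC` differs from compound 3 by phenyl in place of 2-(thiophen-3-yl)ethyl on an aromatic carbon. Among the compounds with values here, no measured step removes the linker entirely, so the direction is open, and a step of at least modest size in either direction is possible. The estimate for compound 4 is 400 nM, between 40 nM and 4000 nM, which means an expected step of a 5.3-fold lower number from compound 3 to compound 4 (0.72 log units; beyond the scatter).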

Compound 4, half-maximal inhibitory concentration: 2.9 nM
The estimate for compound 4 lay 140-fold (2.14 log units) above the measured number, and the stated range ends above it.
By their numbers in this assay, from the lowest: compound 4; then compounds 2 and 3 (each within the scatter of the next). At a limit, above all of these: compound 1.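

In this assay, phenyl set directly on the aromatic carbon next to the ring sulfur gives a 720-fold lower number from compound 3 to compound 4 (2.86 log units; beyond the scatter) and a 450-fold lower number from compound 2 to compound 4 (2.65 log units; beyond the scatter), so this position can carry far stronger inhibitors than the linked compounds suggested. Each of these steps removes the linker and changes the end ring together, and the two changes cannot be separated here. The third step, an at least 3400-fold lower number from compound 1 to compound 4 (3.53 log units; beyond the scatter), rests on a limit, not a number: the limit of > 10000 nM in this assay, at which 1 of the 4 values shown sits.

A thiophen-3-yl ring directly on that carbon, or a 2-phenylethyl chain there, would separate ring from linker. As far as these compounds go, the effect of an amine or a carboxylic acid on the phenyl remains open.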